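The source may hold more compounds than are shown below. What is called first, only, known or untested is meant among the compounds shown, and "the series" means these compounds.

In an ADME assay on microsomes from liver (Rattus norvegicus) for metabolic stability, read by LC-MS, with a stated time of 1 h, at 37 degrees C, tested at 4 uM (on this read-out higher numbers stand for a more stable compound and lower numbers for a less stable compound), compound 1 (`O=C(O)c1cc(-c2cccc(COc3ccc4c(=O)n(CC5CC5)sc4c3)c2)ccc1Cl`) gives 75%, the highest of the three numbers at hand. Sharing no core with it, compound 2 (`COc1ccc(C(=O)O)cc1-c1cccc(COc2ccc3c(c2)CN(C2CCCC2)C3=O)c1`) gives 30%, and compound 3 (`Cc1ccc(C(=O)O)cc1-c1cccc(COc2ccc3c(c2)CN(C2CCCC2)C3=O)c1`) gives 2%.

Compound 4 (`CC(C)Cn1sc2cc(OCc3cccc(-c4ccc(Cl)c(C(=O)O)c4)c3)ccc2c1=O`) keeps the core of compound 1 and differs in one place: isopropyl in place of cyclopropyl on a saturated chain carbon bound to an aromatic nitrogen. In words, this is isopropyl in place of cyclopropyl on a saturated chain carbon bound to an aromatic nitrogen, so that cyclopropylmethyl gives way to isobutyl.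

Going by the values given here, no measured pair makes this exchange. Among the compounds with values here, the only measured step, a number 28 percentage points lower from compound 2 to compound 3 (beyond the scatter), is methyl in place of methoxy on an aromatic carbon, on the other core. It bears on the present case only indirectly, showing that one small exchange can carry this read-out beyond the scatter. A step of similar or smaller size is therefore expected here, and a fall is judged more likely than a rise, though the data do not settle the direction. The estimated step is a number 15 percentage points lower from compound 1 to compound 4 (beyond the scatter). In this assay compound 4 is estimated at 60%, with an expected range from 38% to 80%.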

Compound 4, percent of the compound remaining: 86%
Estimate against measurement, compound 4: 26 percentage points below; the whole stated range lies below it.
By their numbers in this assay, from the lowest: compound 3; then compound 2; then compound 1; then compound 4.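

In this assay, isopropyl in place of cyclopropyl on a saturated chain carbon bound to an aromatic nitrogen gives a number 11 percentage points higher from compound 1 to compound 4 (beyond the scatter), so on this core the three-membered ring can be given up with no loss on this read-out, and the open group stands modestly higher. Going by these compounds alone, the only earlier step was a change on an aromatic carbon on the other core, whereas this pair is the first to speak to this position, and it does so with a change that leaves the count of 3 heavy atoms as it was and removes only the ring. The direction therefore holds for this single pair on this single core, and nothing at hand bears on why the open group gives the higher number.

The compounds shown leave open whether a longer chain, such as a straight hexyl chain, or an amine carried on the same saturated chain carbon would keep the read-out at this level. They also leave open whether the same exchange would move the read-out the same way on the other core.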